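The compounds below may be only part of what the source reports. "The series", "measured", "known", "first", "only" and "open" are said of these compounds alone.

Measured compounds:
- compound 1, `O=C(O)CCCSCCN1C(=O)CC[C@@H]1/C=C/[C@@H](O)Cc1cccc(-c2ccc3[nH]ccc3c2)c1`: in an assay on CHO cells for displacement of a labelled ligand from prostaglandin E2 receptor EP1 subtype (Mus musculus), read by scintillation counting, with a stated time of 20 min (on this read-out lower numbers stand for stronger inhibition and higher numbers for weaker inhibition), compound 1 gives > 10000 nM, a limit of the assay rather than a number.
- compound 2, `O=C(O)CCCSCCN1C(=O)CC[C@@H]1/C=C/[C@@H](O)Cc1cccc(-c2nc3ccccc3s2)c1`: in this assay compound 2 gives > 10000 nM, again a limit.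
- compound 3, `O=C(O)CCCSCCN1C(=O)CC[C@@H]1/C=C/[C@@H](O)Cc1cccc(-c2cc3ccccc3o2)c1`: in this assay compound 3 gives > 10000 nM, also a limit.

Compound 3 thus stands at the limit with the other two; (the limit of > 10000 nM in this assay, at which 3 of the 3 values shown sit). The three swaps on the aromatic carbon, a step that the two limits leave unreadable from compound 1 to compound 2, a step that the two limits leave unreadable from compound 1 to compound 3 and a step that the two limits leave unreadable from compound 2 to compound 3, cannot be sized, since both ends of each sit at the limit. Among the measured compounds shown here, they show only that neither bicyclic ring in that position brought measurable binding.

Compound 4, `O=C(O)CCCSCCN1C(=O)CC[C@@H]1/C=C/[C@@H](O)Cc1cccc(OCc2ccncc2)c1`, is not yet measured. It differs from compound 3 by (pyridin-4-yl)methoxy in place of 1-benzofuran-2-yl on an aromatic carbon. For the measured compounds named here, no measured step covers a change of this kind, so the three unreadable steps give no direction for it. The replacement of a fused bicyclic ring by a benzylic-type ether is a larger departure than the swaps among compounds 1, 2 and 3, so a readable number cannot be excluded, but the starting point is the limit. Compound 4 is expected to remain near the limit, with the expected step of an at least 1.2-fold lower number from compound 3 to compound 4 (0.09 log units; that floor lies within the scatter) not readable with confidence. For compound 4 the estimate is 8000 nM, in the range 1500 nM to 30000 nM.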

Compound 4, inhibition constant: > 10000 nM
Compound 4: a limit, no number (the forecaster's own chance of this, stated with the estimate: 65%); at least 1.2-fold (0.09 log units) between middle value and limit.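

Compound 4 sits at the limit with compound 1, compound 2 and compound 3, so none of its steps to those compounds can be read: the limit of > 10000 nM in this assay, at which 4 of the 4 values shown sit. The compounds shown leave open which group on that aromatic carbon, if any, would give a measurable number in this assay.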